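The source may hold more compounds than are shown below. What is called first, only, known or untested is meant among the compounds shown, and "the series" means these compounds.

Measured compounds:
- compound 1, `CCC(C(=O)N1CCOCC1)N1C(=O)CCC1=O`: 0%
- compound 2, `CCC(C(=O)N1CCN(c2ccccc2)CC1)N1C(=O)CCC1=O`: 25%
- compound 3, `CC(C(=O)N1CCN(c2ccc(Cl)cc2)CC1)N1C(=O)CCC1=O`: 0%

All three were tested in a functional assay on the whole organism (strain Swiss) with Mus musculus as the target, in the maximal electroshock model, with a stated time of 2 h, at a dose of 300 mg/kg by the intraperitoneal route; on this read-out higher numbers stand for a stronger effect at the one dose given and lower numbers for a weaker effect. Compound 1 stands level with compound 3 at the digits given; together they are the lowest of the three numbers, and the gap between them lies within the scatter. The furthest from compound 1 is compound 2, whose number is higher by a gap beyond the scatter. No pair among these three is related by a single change, so no step size can be read from them.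

The next compound, compound 4, is `CC(C(=O)N1CCOCC1)N1C(=O)CCC1=O`. Compared with compound 1 it differs in one place: hydrogen in place of methyl on a saturated chain carbon, two bonds along the chain from an amide-type nitrogen in a ring and a carbonyl carbon. The same change, cut one bond further out, reads ethyl to methyl. Compound 3 carries the shorter chain and gives the same low number as compound 1, though on a different amide partner, so the shown data offer no sign that this change raises activity. The step from compound 1 to compound 4 in this assay is therefore expected to be none beyond the scatter, no change at the digits printed from compound 1 to compound 4 (within the scatter). Compound 4 is estimated at 0%, with a range from 0% to 10%.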

Compound 4, a percentage reported as activity, at one dose (the size of the read-out at that dose, not a potency): 0%
Estimate against measurement, compound 4: no gap at the digits printed; measured number inside the range.
By their numbers in this assay, from the lowest: compounds 1, 3 and 4 (each within the scatter of the next); then compound 2.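

In this assay, within the data shown here, the change from ethyl to methyl on this saturated chain carbon gives the first direct reading at this position, with no change at the digits printed from compound 1 to compound 4 (within the scatter) as the step. Compound 1 already gives 0% here, so this step shows only that the shorter chain brings no measurable activity on this amide partner, and it cannot reveal any loss. No measured property is available that would account for this result.

On these data alone, it remains open whether the same change would have any effect on a partner that gives a number clearly above zero. As far as these compounds go, it is also open whether a longer chain such as propyl, or an amine or a carboxylic acid on this carbon, would move the number on the core of compound 1.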